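A few compounds are considered here, and "the series" means these few. Any claim that something is new, unique, unknown or untested is made for them only; others in the source may bear on it.

Of the compounds shown here, three with a shared core have been read so far in a functional assay on HT-29 cells (Homo sapiens) for inhibition, read by CCK-8 assay, with a stated time of 24 h; on this read-out higher numbers stand for weaker inhibition and lower numbers for stronger inhibition. Compound 1 `Cc1ccccc1-n1cc(-c2ccc(/C=C3\C(=O)Nc4ccccc43)cc2)nn1` gives 8710 nM. Compound 2 `O=C1Nc2ccccc2/C1=C/c1ccc(-c2cn(-c3ccccc3F)nn2)cc1` gives 10500 nM, and the step of a 1.2-fold higher number from compound 1 to compound 2 (0.08 log units; within the scatter) does not separate the two. Compound 3 `O=C1Nc2ccccc2/C1=C/c1ccc(-c2cn(-c3cccc(Cl)c3)nn2)cc1` reads > 20000 nM. That reading is a limit of the assay and not a number, so compound 3 has no exact place on the scale.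

The next compound, compound 4 `O=C1Nc2ccccc2/C1=C/c1ccc(-c2cn(-c3ccc(Cl)c(C(F)(F)F)c3)nn2)cc1`, changes only the group on the aromatic nitrogen: 4-chloro-3-(trifluoromethyl)phenyl in place of 3-chlorophenyl on an aromatic nitrogen. It carries 4-chloro-3-(trifluoromethyl)phenyl in place of 3-chlorophenyl.

The closest guidance comes from the two measured steps that also change this group. One is an at least 2.2-fold higher number from compound 1 to compound 3 (0.36 log units; beyond the scatter), and the other is an at least 1.9-fold higher number from compound 2 to compound 3 (0.27 log units; that floor lies within the scatter). Both are modest and open-ended, since each ends on a limit, and neither involves a trifluoromethyl group. They therefore set no direction for the new change. No step beyond the scatter is expected in this assay, and the estimated move is an at least 1.2-fold lower number from compound 3 to compound 4 (0.09 log units; that floor lies within the scatter). A further reading at the limit would be no surprise. For compound 4 the expected value is 16000 nM, with an estimated range from 6000 nM to 30000 nM.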

Compound 4, half-maximal inhibitory concentration: 9670 nM
Beside the measured number, compound 4's estimate is 1.7-fold (0.22 log units) above it; the range from low to high includes it.
By their numbers in this assay, from the lowest: compounds 1, 4 and 2 (each within the scatter of the next). At a limit, above all of these: compound 3.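

Among the compounds shown here, on the aromatic nitrogen in this assay, 4-chloro-3-(trifluoromethyl)phenyl in place of 3-chlorophenyl gives an at least 2.0-fold lower number from compound 3 to compound 4 (0.31 log units; beyond the scatter), the first step that returns a compound from the top of the scale to a measured value. Compound 3 remains the only compound that reads as a limit and not as a number, so the true size of this step stays open: the limit of > 20000 nM in this assay, at which 1 of the 4 values shown sits.

The new group also falls level with the two smaller groups, with a 1.1-fold lower number from compound 2 to compound 4 (0.04 log units; within the scatter) and a 1.1-fold higher number from compound 1 to compound 4 (0.05 log units; within the scatter), which shows that a chlorine on the phenyl ring does not by itself place a compound at the limit and that this position accepts the larger group with no step beyond the scatter.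

The compounds shown do not separate the contribution of the trifluoromethyl group from that of the chlorine's place on the ring. They also leave open how an amine or a carboxylic acid on this phenyl ring, or a simple alkyl chain on the nitrogen in place of the ring, would read in this assay.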